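Chloro in place of hydrogen on compound 3

The source may report more compounds than this note shows. Statements on the series, on what has been measured and on what is new or still open speak of the compounds shown alone.

Three compounds share one core. Compound 1 `O=C(Nc1cccc(-n2cc(-c3ccncc3)c(-c3ccc(Cl)c(O)c3)n2)c1)Nc1cccc(C(F)(F)F)c1` gives 1290 nM in a functional assay on ACHN cells (Homo sapiens) for inhibition, read by sulforhodamine B assay, with a stated time of 48 h; on this read-out higher numbers stand for weaker inhibition of growth and lower numbers for stronger inhibition of growth. Compound 2 `COc1cc(-c2nn(-c3cccc(NC(=O)Nc4cc(C(F)(F)F)cc(C(F)(F)F)c4)c3)cc2-c2ccncc2)ccc1Cl` gives 491 nM. Compound 3 `COc1cc(-c2nn(-c3cccc(NC(=O)Nc4cccc(C(F)(F)F)c4)c3)cc2-c2ccncc2)ccc1Cl` gives 656 nM, the second highest of the three numbers, although all three fall within the usual scatter of one another. Compound 4 `COc1cc(-c2nn(-c3cccc(NC(=O)Nc4ccc(Cl)c(C(F)(F)F)c4)c3)cc2-c2ccncc2)ccc1Cl` differs from compound 3 by chloro in place of hydrogen on an aromatic carbon. Among the compounds with values here, two measured steps bear on this change: a 2.0-fold lower number from compound 1 to compound 3 (0.29 log units; within the scatter) and, on the same ring that receives the new chloro, a 1.3-fold higher number from compound 2 to compound 3 (0.13 log units; within the scatter). Both steps are small, so only a modest change is expected here, a 1.5-fold lower number from compound 3 to compound 4 (0.16 log units; within the scatter), with its direction uncertain. Compound 4 is therefore estimated at 450 nM, within a range from 150 nM to 1500 nM.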

Compound 4, concentration for 50% growth inhibition: 1100 nM
Compound 4: the middle estimate sits 2.4-fold (0.39 log units) below what was measured, and the stated range covers the measured number.
By their numbers in this assay, from the lowest: compounds 2, 3, 4 and 1 (each within the scatter of the next, the first and the last beyond it).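

Placing a chloro on this carbon, ortho to a trifluoromethyl group and para to a large group, gives a 1.7-fold higher number from compound 3 to compound 4 (0.22 log units; within the scatter) in this assay, so this position accepts a chloro without a change beyond the scatter. The same ring also shows only a 1.3-fold higher number from compound 2 to compound 3 (0.13 log units; within the scatter) when a second trifluoromethyl group is exchanged for hydrogen elsewhere on it. Nothing available explains the chloro result.

Still open, as far as these compounds go, is whether an amine or a carboxylic acid on this same carbon would shift the number beyond the scatter. A chloro on this ring without the trifluoromethyl group also remains untested among the compounds shown.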